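Lengthening the Amide Chain of Compound 2

This account rests on a few compounds, and the source may have more. Where it says the series, first, only, none or still open, it means among the compounds named here.

Of the compounds shown here, three sharing one core have been measured in a functional assay on HT-29 cells (Homo sapiens) for antiproliferative activity, read by MTT assay, with a stated time of 72 h; a lower number here means a stronger inhibitor, a higher number a weaker inhibitor. Compound 1 `CCNC(=O)c1cc(Oc2ccc(NC(=O)c3cc4cccnc4n(-c4ccc(F)cc4)c3=O)cc2)ccn1` gives 190 nM. Compound 2 `CCNC(=O)c1cc(Oc2ccc(NC(=O)c3cc4cccnc4n(-c4ccc(Cl)cc4)c3=O)cc2)ccn1` gives 330 nM, the second highest of the three numbers. Compound 3 `CCNC(=O)c1cc(Oc2ccc(NC(=O)c3cc4cccnc4n(-c4ccc(Br)cc4F)c3=O)cc2)ccn1` gives 2070 nM. Compound 2 stands nearest to compound 1, with a 1.7-fold higher number from compound 1 to compound 2 (0.24 log units; within the scatter), and furthest from compound 3, with a 6.3-fold higher number from compound 2 to compound 3 (0.80 log units; beyond the scatter); the step of an 11-fold higher number from compound 1 to compound 3 (1.04 log units; beyond the scatter) is the largest seen.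

Compound 4 `CCCNC(=O)c1cc(Oc2ccc(NC(=O)c3cc4cccnc4n(-c4ccc(Cl)cc4)c3=O)cc2)ccn1` differs from compound 2 by methyl in place of hydrogen on a saturated chain carbon, two bonds along the chain from an amide-type nitrogen. For the measured compounds named here, none of the measured steps touches this part of the molecule: all three alter the aryl group on the aromatic nitrogen, while the amide chain is ethyl in every measured compound. Nothing measured therefore bears directly on the change, and no step beyond the scatter is expected in this assay from compound 2 to compound 4. The estimate for compound 4 is 330 nM, expected to lie between 150 nM and 750 nM. The expected step is no change at the digits printed from compound 2 to compound 4 (within the scatter).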

Compound 4, half-maximal inhibitory concentration: 390 nM
The estimate for compound 4 lay 1.2-fold (0.07 log units) below the measured number, within the range that was stated.
By their numbers in this assay, from the lowest: compounds 1, 2 and 4 (each within the scatter of the next, the first and the last beyond it); then compound 3.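

For the compounds shown here, the earlier compounds changed only the aryl group on the aromatic nitrogen, so this is the first reading on the amide chain itself. In this assay, going from ethyl to propyl on the compound 2 scaffold gives a 1.2-fold higher number from compound 2 to compound 4 (0.07 log units; within the scatter), so this added methyl, two bonds along the chain from an amide-type nitrogen, produces no change beyond the scatter, unlike the larger steps seen at the aryl group. No measurement here explains why the number holds at this position.

This single step leaves open whether a longer chain such as butyl, a branched chain such as isopropyl, or a chain ending in an amine or a carboxylic acid would also stay within the scatter. It also leaves open whether propyl would behave the same way alongside the 4-fluorophenyl or 4-bromo-2-fluorophenyl group.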